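Arylurea series: swapping the para substituent of compound 2

This account rests on a few compounds, and the source may have more. Where it says the series, first, only, none or still open, it means among the compounds named here.

Measured so far:
- compound 1, `CCCCCCc1ccc(NC(=O)N[C@H](C)c2ccccc2)cc1`, gives in an ADME assay on the whole organism with Oryza sativa as the target, tested at 1 uM (a lower number here means a stronger effect, a higher number a weaker effect of the compound at the concentration tested), a value of 101%
- compound 2, `CCOC(=O)c1ccc(NC(=O)N[C@H](C)c2ccccc2)cc1`, gives in this assay a value of 100%

Compound 2 holds the lowest of the two numbers, but its nearest neighbour, compound 1, sits a number 1 percentage points lower from compound 1 to compound 2 (within the scatter), so the two cannot be told apart.

Compound 3, `C[C@@H](NC(=O)Nc1ccc(F)cc1)c1ccccc1`, is to be measured in this assay. It differs from compound 2 by fluoro in place of ethoxycarbonyl on an aromatic carbon. Within the data shown here, the only measured step that touches this position, the change from hexyl to ethoxycarbonyl on the same aromatic carbon, gave a number 1 percentage points lower from compound 1 to compound 2 (within the scatter). Two groups of very different make-up at this carbon thus left the read-out unchanged, and nothing in the data points to a move beyond the scatter for a third group there.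

Compound 3 is therefore expected to give 99%, within 90% to 106%, an estimated step of a number 1 percentage points lower from compound 2 to compound 3 (within the scatter).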

Compound 3, a percentage reported as activity, at one concentration (the size of the read-out at that concentration, not a potency): 96%
The estimate for compound 3 lay 3 percentage points above the measured number; low and high end bracket the measured number.
By their numbers in this assay, from the lowest: compounds 3, 2 and 1 (each within the scatter of the next).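

In this assay fluoro in place of ethoxycarbonyl gives a number 4 percentage points lower from compound 2 to compound 3 (within the scatter) and fluoro in place of hexyl gives a number 5 percentage points lower from compound 1 to compound 3 (within the scatter) at the same aromatic carbon. Among these compounds, the earlier pair offered only two groups of several heavy atoms, whereas the set now includes fluoro, with 1 heavy atom and no hydrogen-bond acceptors, and still no step at this position lies beyond the scatter. No supporting measurement is available to explain this flat result.

Going by these compounds, it remains open whether any group on this aromatic carbon, such as an amine, a carboxylic acid or a nitrile, can produce a step beyond the scatter. Also open, on these data alone, is whether a change elsewhere in the shared core moves the read-out at all.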